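Swapping the Phenyl Group on a Very Weak Inhibitor

This account rests on a few compounds, and the source may have more. Where it says the series, first, only, none or still open, it means among the compounds named here.

Compound 2 `Fc1cccc(-c2nc(Nc3ccccc3Cl)c3cc(F)ccc3n2)c1` and compound 1 `Fc1cccc(-c2nc(Nc3ccccc3)c3cc(F)ccc3n2)c1` share one core and differ only at the phenyl attached to the amine nitrogen. In a functional assay on COLO 205 cells (Homo sapiens) for cytotoxicity, read by MTT assay, with a stated time of 48 h (a higher number here means a weaker inhibitor, a lower number a stronger inhibitor), compound 1 gives 49700 nM. For compound 2, this assay reports only a limit, > 50000 nM. Within the data shown here, the single measured step, a number no lower from compound 1 to compound 2 (the limit leaves the size open), is therefore of unknown size, and the limit of > 50000 nM in this assay, at which 1 of the 2 values shown sits, shows that compound 2 is one of the two values sitting on that limit. Compound 3 `Oc1cccc(Nc2nc(-c3cccc(F)c3)nc3ccc(F)cc23)c1` carries 3-hydroxyphenyl in place of 2-chlorophenyl on a nitrogen on an aromatic ring. Among the measured compounds shown here, no measured step involves a hydroxyl group, so the move from compound 2 to compound 3 has nothing directly comparable behind it; compound 1 and compound 2 show only that both sit at the weak end of the scale. The estimate for compound 3 in this assay is 45000 nM, with a range from 10000 nM to 100000 nM. The step this implies, an at least 1.1-fold lower number from compound 2 to compound 3 (0.04 log units; that floor lies within the scatter), is expected to stay within the scatter.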

Compound 3, half-maximal inhibitory concentration: > 50000 nM
Compound 3 was reported as a limit; the forecaster's own chance of this, stated with the estimate: 50%; middle value at least 1.1-fold (0.04 log units) from the limit.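

In this assay compound 3 gives > 50000 nM, which is a limit of the assay and not a number. A hydroxyl on this phenyl brings a hydrogen-bond donor and a hydrogen-bond acceptor that the 2-chlorophenyl lacks, yet it does not move the compound away from the weak end of the scale, and replacing hydrogen with hydroxy gives a number no lower from compound 1 to compound 3 (the limit leaves the size open). The step between compound 2 and compound 3 cannot be read, because both values are limits: the limit of > 50000 nM in this assay, at which 2 of the 3 values shown sit.

On these data alone, how far compound 2 and compound 3 lie beyond that limit stays unknown. Also open, as far as these compounds go, is whether an amine or a carboxylic acid on this phenyl, or a longer chain in place of the ring on the nitrogen, would give a value that can be read.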